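A few compounds are considered here, and "the series" means these few. Any claim that something is new, unique, unknown or untested is made for them only; others in the source may bear on it.

Measured so far in a functional assay on HL-60 cells (Homo sapiens) for inhibition; a higher number here means a weaker inhibitor, a lower number a stronger inhibitor:
- compound 1 (`COc1ccc(-c2cc(=O)n(Cc3cccnc3)nc2-c2ccc(OC)cc2)cc1`): 430 nM
- compound 2 (`COc1ccc(-c2cc(=O)n(CC3CC3)nc2-c2ccc(OC)cc2)cc1`): 1800 nM

Among the compounds with values here, of these two values, compound 2 (1800 nM) has the higher number and is the weaker inhibitor, with compound 1 as its only neighbour.

Compound 3 (`C=CCn1nc(-c2ccc(OC)cc2)c(-c2ccc(OC)cc2)cc1=O`) has not yet been measured. It differs from compound 2 at the same place that separates the two measured compounds (vinyl in place of cyclopropyl on a saturated chain carbon bound to an aromatic nitrogen): vinyl in place of cyclopropyl on a saturated chain carbon bound to an aromatic nitrogen. Cut one bond further out, this reads cyclopropylmethyl to allyl.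

Within the data shown here, only one measured step bears on this place, a modest one (a 4.2-fold higher number from compound 1 to compound 2 (0.62 log units; beyond the scatter)). That step exchanged pyridin-3-yl for cyclopropyl, whereas the present exchange is between two groups of carbon only. One step is a thin basis, so the range stays wide. No step beyond the scatter is expected in this assay, in either direction. The estimated change is small (a 1.1-fold lower number from compound 2 to compound 3 (0.02 log units; within the scatter)). Compound 3 is estimated at 1700 nM (expected range 700 nM to 4000 nM).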

Compound 3, half-maximal inhibitory concentration: > 100000 nM
Compound 3: a limit, no number (the forecaster's own chance of this, stated with the estimate: 5%); middle value at least 58-fold (1.76 log units) away from the limit.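

In this assay compound 3 gives a limit and not a number: the limit of > 100000 nM in this assay, at which 1 of the 3 values shown sits.

This position, on a saturated chain carbon bound to an aromatic nitrogen, proves far more sensitive than the first pair indicated, since an exchange between two groups of carbon only, vinyl in place of cyclopropyl, gives an at least 55-fold higher number from compound 2 to compound 3 (1.74 log units; beyond the scatter), well beyond the earlier 4.2-fold higher number from compound 1 to compound 2 (0.62 log units; beyond the scatter). Against the pyridin-3-yl group, the change reaches an at least 230-fold higher number from compound 1 to compound 3 (2.36 log units; beyond the scatter), and among these three compounds the two substituents that carry a ring, pyridin-3-yl and cyclopropyl, give numbers, while the ring-free allyl group gives only a limit, with no compound here going against that pattern.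

The compounds shown cannot say whether the loss of the ring or the presence of the double bond goes with this drop, and a saturated propyl chain would bear directly on that question. On these data alone, whether a larger ring on the same chain carbon, such as cyclohexyl or phenyl, keeps or improves on the value of compound 1 also stays open.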